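Working notes: three measured compounds, one pending

The compounds below may be only part of what the source reports. "The series", "measured", "known", "first", "only" and "open" are said of these compounds alone.

Measured so far in a functional assay on CHO cells for antagonist activity at transient receptor potential cation channel subfamily V member 1 (Homo sapiens), read by fluorescence and calcium flux; on this read-out lower numbers stand for stronger inhibition and higher numbers for weaker inhibition:
compound 1 `COCCCNC(=O)c1noc(-c2ccc(C(F)(F)F)cc2)c1Cl` gives 2210 nM
compound 2 `O=C(NC1CCCC1)c1noc(-c2ccc(C(F)(F)F)cc2)c1F` gives 112 nM
compound 3 `O=C(NC1CCCC1)c1noc(-c2ccc(Cl)cc2)c1Br` gives 370 nM

Compound 3 stands second highest of the three numbers. Its nearest neighbour is compound 2, whose lower number lies beyond the usual scatter, so compound 2 shows the stronger inhibition of the two. The furthest is compound 1, whose higher number also lies beyond the scatter. Of the three, only compound 3 carries the 4-chlorophenyl group, so nothing measured yet separates the effect of that group from the rest.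

Compound 4 `O=C(NC1CCCC1)c1noc(-c2cccc(Cl)c2)c1Br` is the same set of atoms joined differently: 3-chlorophenyl in place of 4-chlorophenyl on an aromatic carbon

Within the data shown here, no measured pair shows such a move of a chloro around the phenyl, so the expected step rests on compound 3 alone. The expectation is a modest rise in the number, beyond the scatter, estimated as a 2.7-fold higher number from compound 3 to compound 4 (0.43 log units; beyond the scatter). Compound 4 is therefore expected to give about 1000 nM, within a range from 300 nM to 4000 nM.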

Compound 4, half-maximal inhibitory concentration: 4220 nM
Compound 4: the middle estimate sits 4.2-fold (0.63 log units) below what was measured; the whole stated range lies below it.
By their numbers in this assay, from the lowest: compound 2; then compound 3; then compounds 1 and 4 (each within the scatter of the next).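

In this assay, among these compounds, 3-chlorophenyl in place of 4-chlorophenyl gives an 11-fold higher number from compound 3 to compound 4 (1.06 log units; beyond the scatter), the first step that changes one place alone. Among the compounds shown here, with the atoms unchanged, the read-out at this aromatic carbon depends strongly on where the chlorine sits on the phenyl, which the earlier compounds, differing in more than one place, could not show. No measurement at hand explains the size of this step.

The compounds shown leave open how an unsubstituted phenyl, or a phenyl bearing a methoxy group or a nitrile, would read at this place. On these data alone, it also remains open whether moving the chlorine gives a step of similar size with a fluoro group in place of the bromo group.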